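The source may report more compounds than this note shows. Statements on the series, on what has been measured and on what is new or still open speak of the compounds shown alone.

In a functional assay on A549 cells (Homo sapiens) for cytotoxicity, with a stated time of 48 h (a higher number here means a weaker inhibitor, a lower number a stronger inhibitor), two compounds on a shared core have been measured so far. Compound 1 `CCCCOc1ccc2oc(/C=C/[S+](C)[O-])cc(=O)c2c1`, which carries butoxy, gives 1400 nM. Compound 2 `C[S+]([O-])/C=C/c1cc(=O)c2cc(C#N)ccc2o1`, with cyano at that place, gives > 10000 nM, which is a limit of the assay and not a number.

Compound 3 `CCCOc1ccc2oc(/C=C/[S+](C)[O-])cc(=O)c2c1` departs from compound 2 at that same aromatic carbon, with propoxy in place of cyano on an aromatic carbon.

Within the data shown here, one measured step bears on this change. It is an at least 7.1-fold higher number from compound 1 to compound 2 (0.85 log units; beyond the scatter), with cyano in place of butoxy, and it lies beyond the scatter. Going by these compounds, its true size remains open, since only a limit stands at one end. The step now in question runs the other way, removing cyano and restoring an oxygen-linked chain, though propoxy rather than butoxy. A move toward a lower number in this assay is therefore expected, of about the size of the measured step, which would bring compound 3 close to compound 1 at 1400 nM. The expected change is an at least 4.5-fold lower number from compound 2 to compound 3 (0.65 log units; beyond the scatter). For compound 3 the estimated value is 2200 nM, with an expected range from 800 nM to 6500 nM.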

Compound 3, half-maximal inhibitory concentration: 1100 nM
Estimate against measurement, compound 3: 2.0-fold (0.30 log units) above; the range from low to high includes it.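

In this assay, the swap at this aromatic carbon now has a second reading, from the other side: replacing cyano with propoxy gives an at least 9.0-fold lower number from compound 2 to compound 3 (0.95 log units; beyond the scatter), so two different oxygen-linked chains on the shared core, butoxy and propoxy, now each stand apart from cyano, where before only butoxy did. Between those two chains the step is a 1.3-fold lower number from compound 1 to compound 3 (0.10 log units; within the scatter), so in this assay butoxy and propoxy cannot be told apart at this position. Compound 2 stands at a limit of the assay and not a number, so the true size of its steps to both chains remains open: the limit of > 10000 nM in this assay, at which 1 of the 3 values shown sits.

The compounds shown do not separate the role of the linking oxygen from that of the chain, which a plain propyl group at the same aromatic carbon would address. They also leave open how far this level holds beyond these two chains, whether with the shorter methoxy, a longer chain such as hexyloxy, or a group of another kind such as an amine or a carboxylic acid.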